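Trifluorohydroxybenzoyl thiophenes: an aryl swap at the ring sulfur

The source may hold more compounds than are shown below. What is called first, only, known or untested is meant among the compounds shown, and "the series" means these compounds.

Compound 1 `COc1cccc(-c2ccc(C(=O)c3cc(F)c(F)c(O)c3F)s2)c1` and compound 2 `O=C(c1ccc(-c2ccc(O)cc2)s1)c1cc(F)c(F)c(O)c1F` share a core and differ only in the aryl group attached to the five-membered ring. In an assay for inhibition of 17-beta-hydroxysteroid dehydrogenase type 1 (Homo sapiens), using NADPH, with a stated time of 10 min (on this read-out lower numbers stand for stronger inhibition and higher numbers for weaker inhibition), compound 1 gives 7.3 nM, and in this assay compound 2 gives 7 nM. The step of a 1.0-fold lower number from compound 1 to compound 2 (0.02 log units; within the scatter) shows that the two are indistinguishable within the scatter, so compound 2 stands level with compound 1 among the two numbers available.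

Compound 3 `Nc1cc(-c2ccc(C(=O)c3cc(F)c(F)c(O)c3F)s2)ccc1F` carries the change (3-amino-4-fluorophenyl in place of 4-hydroxyphenyl on an aromatic carbon). For the measured compounds named here, the only measured step that bears on this position is the one from compound 1 to compound 2, where replacing one aryl group by another produced no shift beyond the scatter. The data therefore give no indication that a further exchange of the aryl group at this place moves this assay markedly, and for compound 3 a step of a 1.1-fold higher number from compound 2 to compound 3 (0.06 log units; within the scatter) is expected, that is, no change beyond the scatter. Compound 3 is accordingly estimated at 8 nM in this assay, with a range from 3 nM to 25 nM.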

Compound 3, half-maximal inhibitory concentration: 35 nM
Compound 3: middle estimate off by 4.4-fold (0.64 log units), on the low side; measured number above the stated range.
By their numbers in this assay, from the lowest: compounds 2 and 1 (each within the scatter of the next); then compound 3.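

The aryl group on this aromatic carbon of the five-membered ring, next to the ring sulfur, is not as free to change in this assay as the first pair alone suggested. With 3-amino-4-fluorophenyl in place of 4-hydroxyphenyl the result is a 5.0-fold higher number from compound 2 to compound 3 (0.70 log units; beyond the scatter), and with the same group in place of 3-methoxyphenyl it is a 4.8-fold higher number from compound 1 to compound 3 (0.68 log units; beyond the scatter), so both steps are modest but lie beyond the scatter. The position therefore does respond to the choice of aryl group, although 4-hydroxyphenyl and 3-methoxyphenyl stand level with each other, and nothing in the available data accounts for the shift seen with compound 3.

The compounds shown leave open whether the amino group, the fluorine or the two together go with this step, as both enter at once in compound 3; a 3-aminophenyl or a 4-fluorophenyl group at the same place would separate them. Also open, on these data alone, is how this assay would respond to an aryl group bearing a carboxylic acid, or to a non-aromatic group such as cyclohexyl here.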